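A few compounds are considered here, and "the series" means these few. Any claim that something is new, unique, unknown or untested is made for them only; others in the source may bear on it.

Working notes on the series in a functional assay on MCF7 cells (Homo sapiens) for antiproliferative activity, read by MTT assay; a lower number here means a stronger inhibitor, a higher number a weaker inhibitor. Compound 1 (`COc1cc2c(Oc3ccc(NC(=O)Nc4ccccc4)cc3)ccnc2cc1OCCCCCCC(=O)NO`) gives 1040 nM and compound 2 (`COc1cc2c(Oc3ccc(NC(=O)Nc4cccc(C)c4)cc3)ccnc2cc1OCCCCCCC(=O)NO`) gives 1240 nM, which amounts to a 1.2-fold higher number from compound 1 to compound 2 (0.08 log units; within the scatter). Compound 3 (`COc1cc2c(Oc3ccc(NC(=O)Nc4ccc(C)cc4C)cc3)ccnc2cc1OCCCCCCC(=O)NO`) gives 3430 nM, the highest number of the three, reached by a 3.3-fold higher number from compound 1 to compound 3 (0.52 log units; beyond the scatter) and by a 2.8-fold higher number from compound 2 to compound 3 (0.44 log units; beyond the scatter).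

Compound 4 (`COc1cc2c(Oc3ccc(NC(=O)N/N=C/c4ccc(F)cc4)cc3)ccnc2cc1OCCCCCCC(=O)NO`) is not yet measured. The change is a group of 9 heavy atoms (7 carbon, 1 nitrogen, 1 fluorine; one six-membered aromatic ring of carbon only) in place of a group of 8 heavy atoms (8 carbon; one six-membered aromatic ring of carbon only), on an amide-type nitrogen, and the entering group also holds 1 double bond outside aromatic rings. Going by the values given here, no measured compound carries a group of this kind, so the guide is limited to the changes on this same nitrogen. Those remain modest, the largest being a 3.3-fold higher number from compound 1 to compound 3 (0.52 log units; beyond the scatter). As far as these compounds go, removing 2,4-dimethylphenyl is expected to recover part of that step, though the new group is untested and the range stays wide. The expected change is a 2.1-fold lower number from compound 3 to compound 4 (0.33 log units; beyond the scatter), a modest move toward a lower number in this assay. Compound 4 is estimated at 1600 nM, with an expected range of 550 nM to 4500 nM.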

Compound 4, half-maximal inhibitory concentration: 1360 nM
Beside the measured number, compound 4's estimate is 1.2-fold (0.07 log units) above it, and the stated range covers the measured number.
By their numbers in this assay, from the lowest: compounds 1, 2 and 4 (each within the scatter of the next); then compound 3.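

The earlier compounds shown here varied only methyl groups on the phenyl ring at this amide-type nitrogen, and compound 4 shows that a group of a different kind, with a fluorine and a double bond outside aromatic rings, can stand here in this assay without separating from the two lowest numbers: a 1.1-fold higher number from compound 2 to compound 4 (0.04 log units; within the scatter) and a 1.3-fold higher number from compound 1 to compound 4 (0.12 log units; within the scatter). Going by these compounds alone, the step of a 2.5-fold lower number from compound 3 to compound 4 (0.40 log units; beyond the scatter) leaves compound 3 as the only compound set apart, with steps beyond the scatter to all three others. Nothing available gives a cause for these steps.

The compounds shown do not separate the contribution of the fluorine from that of the rest of the entering group. They also leave open how the number would respond to a saturated carbon chain in place of the double bond, or to an amine or a carboxylic acid in place of the fluorine.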